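Swapping the amide arm on the triazole for 4-nitrophenyl

The source may report more compounds than this note shows. Statements on the series, on what has been measured and on what is new or still open speak of the compounds shown alone.

Compound 1 `CCOC(=O)C1=Cc2ccccc2OC1(OCc1cn(CC(=O)Nc2cccc(Cl)c2)nn1)C(F)(F)F` gives 12800 nM in a functional assay on A549 cells (Homo sapiens) for inhibition, read by MTT assay, with a stated time of 24 h; a higher number here means a weaker inhibitor, a lower number a stronger inhibitor.
Compound 2 `CCOC(=O)C1=Cc2ccccc2OC1(OCc1cn(CC(=O)NC2CCCCC2)nn1)C(F)(F)F` gives 9900 nM in this assay.
Compound 3 `CCOC(=O)C1=Cc2ccccc2OC1(OCc1cn(CC(=O)Nc2ccccc2Br)nn1)C(F)(F)F` gives > 150000 nM in this assay, which is a limit of the assay and not a number.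

Compound 3 thus stands at the weak end of this small set: the steps of an at least 11-fold higher number from compound 1 to compound 3 (1.06 log units; beyond the scatter) and an at least 15-fold higher number from compound 2 to compound 3 (1.18 log units; beyond the scatter) are both large, whereas a 1.3-fold lower number from compound 1 to compound 2 (0.11 log units; within the scatter) stays within the scatter. Compound 4 `CCOC(=O)C1=Cc2ccccc2OC1(OCc1cn(-c2ccc([N+](=O)[O-])cc2)nn1)C(F)(F)F` differs from compound 3 by 4-nitrophenyl in place of ((2-bromophenyl)carbamoyl)methyl on an aromatic nitrogen. For the measured compounds named here, no measured step removes this whole arm, so the measured steps only show that the 2-bromophenyl amide is the one group sitting at the limit (the limit of > 150000 nM in this assay, at which 1 of the 3 values shown sits). The expected step is an at least 6.0-fold lower number from compound 3 to compound 4 (0.77 log units; beyond the scatter), back toward the numbers of compounds 1 and 2, though with wide uncertainty. Compound 4 is therefore estimated at 25000 nM, with a range from 5000 nM to 150000 nM.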

Compound 4, half-maximal inhibitory concentration: > 150000 nM
Compound 4: a limit, no number; the forecaster's own chance of this, stated with the estimate: 30%; at least 6.0-fold (0.77 log units) between middle value and limit.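

In this assay, replacing the whole amide arm with 4-nitrophenyl brings an at least 15-fold higher number from compound 2 to compound 4 (1.18 log units; beyond the scatter) and an at least 11-fold higher number from compound 1 to compound 4 (1.06 log units; beyond the scatter). Weak results at this position are thus no longer confined to the 2-bromophenyl amide, and a group without the amide hydrogen ends at the same place: the limit of > 150000 nM in this assay, at which 2 of the 4 values shown sit. Compound 3 and compound 4 are both limits and not numbers, so the step between them cannot be read.

Still open, going by these compounds, is whether the result follows the missing amide arm or the nitro group itself. A 4-aminophenyl on this nitrogen, or a 4-nitrophenyl at the end of the amide arm, would separate the two.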